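Clearance step from compound 2 to compound 3

The source may report more compounds than this note shows. Statements on the series, on what has been measured and on what is new or still open speak of the compounds shown alone.

In an ADME assay on cells (Hepatocyte, Rattus norvegicus, strain Wistar) for pharmacokinetics, read by LC-MS, with a stated time of 90 min, tested at 1 uM (a higher number here means faster removal of the compound, a lower number slower removal), compound 2 (`COc1cc(C(=O)N2CCC(O)C(C)C2)cc2nc(NCc3cncc(Cl)c3)oc12`) gives 40 mL/min/kg as the higher of the two numbers at hand, and compound 1 (`COc1cc(C(=O)N2CCC(O)C(C)C2)cc2nc(NCc3cc(Cl)ccn3)oc12`) gives 14.3 mL/min/kg as the lower. Compound 3 (`COc1cc(C(=O)N2CCC(O)C(C)C2)cc2nc(NC3(c4cccc(Cl)c4)CC3)oc12`) is still unmeasured, and its change is 1-(3-chlorophenyl)cyclopropyl in place of (5-chloropyridin-3-yl)methyl on a nitrogen on an aromatic ring on the shared core. Within the data shown here, the only measured step that bears on it is a 2.8-fold higher number from compound 1 to compound 2 (0.45 log units; beyond the scatter) and it is modest, with the chain carbon kept. Among the measured compounds shown here, no measured compound carries the 1-(3-chlorophenyl)cyclopropyl group, so the direction remains uncertain. With compound 2 at 40 mL/min/kg as the upper of the two numbers, a step of about the same modest size is expected, more likely downward than upward. The expected step is a 2.0-fold lower number from compound 2 to compound 3 (0.30 log units; within the scatter) with wide uncertainty. For compound 3 the estimate is 20 mL/min/kg with an expected range from 8 mL/min/kg to 55 mL/min/kg in this series.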

Compound 3, clearance: 46.7 mL/min/kg
Estimate against measurement, compound 3: 2.3-fold (0.37 log units) below, within the range that was stated.
By their numbers in this assay, from the lowest: compound 1; then compounds 2 and 3 (each within the scatter of the next).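

In this assay, the step of a 1.2-fold higher number from compound 2 to compound 3 (0.07 log units; within the scatter) shows that 1-(3-chlorophenyl)cyclopropyl can take the place of (5-chloropyridin-3-yl)methyl on this nitrogen with no readable change in clearance. The step of a 3.3-fold higher number from compound 1 to compound 3 (0.51 log units; beyond the scatter) sets compound 1 apart from both others by more than the scatter, so among these three compounds, only the (4-chloropyridin-2-yl)methyl group gives a distinct number. No measurement offered here accounts for these numbers. Going by these compounds, the entering group differs from the leaving one in both the cyclopropyl ring and the ring nitrogen, so the share of each stays open. Also open, on these data alone, is how a 3-chlorobenzyl group or a 1-(4-chloropyridin-2-yl)cyclopropyl group on the same nitrogen would read, and whether the cyclopropyl ring would keep compound 1's lower number.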